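This account rests on a few compounds, and the source may have more. Where it says the series, first, only, none or still open, it means among the compounds named here.

Compound 1 `O=C(Nc1ccc(I)cc1)c1cncc(N2CC3CC(C2)N3)c1`: 103 nM in an assay on cells for displacement of a labelled ligand from Neuronal acetylcholine receptor; alpha3/beta4 (Homo sapiens); on this read-out lower numbers stand for stronger inhibition and higher numbers for weaker inhibition
Compound 2 `O=C(c1cncc(N2CC3CC(C2)N3)c1)N1CCc2ccccc2C1`: 21 nM in this assay

Of these two numbers, compound 1 has the higher one; compound 2 lies at a lower value, a gap that goes beyond the usual scatter. Compound 3 `O=C(Nc1ccccc1F)c1cncc(N2CC3CC(C2)N3)c1` differs from compound 1 in one place: 2-fluorophenyl in place of 4-iodophenyl on an amide-type nitrogen. Within the data shown here, no measured pair shows a change of this kind, so the size of the step in this assay is open; a small step, possibly none beyond the scatter, is expected, if anything towards a higher number. The step from compound 1 to compound 3 is expected to be a 1.9-fold higher number from compound 1 to compound 3 (0.29 log units; within the scatter). Compound 3 is estimated at 200 nM, within 60 nM to 700 nM.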

Compound 3, inhibition constant: 102 nM
For compound 3 the middle estimate is 2.0-fold (0.29 log units) above the measured one, and the stated range covers the measured number.
By their numbers in this assay, from the lowest: compound 2; then compounds 3 and 1 (each within the scatter of the next).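

In this assay, among these compounds, the change from 4-iodophenyl to 2-fluorophenyl on the amide-type nitrogen gives a 1.0-fold lower number from compound 1 to compound 3 (0.00 log units; within the scatter), the first measured step at this place. The two aryl groups are thus interchangeable here on this read-out, although both the halogen and its place on the ring differ. Nothing measured explains this equivalence.

The compounds shown do not separate the two differences, which 4-fluorophenyl or 2-iodophenyl would do. Going by these compounds, it also remains open whether an unsubstituted phenyl or a ring carrying an amine or a carboxylic acid would fare the same.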